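The source may report more compounds than this note shows. Statements on the series, on what has been measured and on what is new or still open speak of the compounds shown alone.

Measured in a functional assay on PBMC cells (Homo sapiens) for inhibition, read by HTRF, with stated times of 15 min and 24 h; a lower number here means a stronger inhibitor, a higher number a weaker inhibitor:

- Compound 1 `O=C(Nc1ccc2c(c1)B(O)OC2)c1ccccc1C(F)(F)F` gives 4400 nM
- Compound 2 `Cc1ccccc1C(=O)Nc1ccc2c(c1)B(O)OC2` gives > 100000 nM as a limit of the assay
- Compound 3 `O=C(Nc1ccc2c(c1)B(O)OC2)c1ccccc1OC(F)(F)F` gives > 100000 nM as a limit of the assay

Among the compounds with values here, compound 1 holds the only true number here, while compound 2 and compound 3 sit at the limit of > 100000 nM in this assay, at which 2 of the 3 values shown sit, and give no exact value. Compound 4 `O=C(Nc1ccc2c(c1)B(O)OC2)c1cc(C(F)(F)F)ccc1C(F)(F)F` keeps all of compound 1 and differs by trifluoromethyl in place of hydrogen on an aromatic carbon, para to a trifluoromethyl group.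

Within the data shown here, two measured steps bear on this, both large: an at least 22-fold higher number from compound 1 to compound 2 (1.35 log units; beyond the scatter) and an at least 22-fold higher number from compound 1 to compound 3 (1.35 log units; beyond the scatter). Both replace the existing trifluoromethyl group rather than a hydrogen, so they are only a loose guide. A moderately higher number is still expected in this assay for compound 4. The expected change is a 2.7-fold higher number from compound 1 to compound 4 (0.44 log units; beyond the scatter) by this estimate. Compound 4 is estimated at 12000 nM with an expected range from 2000 nM to 80000 nM.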

Compound 4, half-maximal inhibitory concentration: 3000 nM
The estimate for compound 4 lay 4.0-fold (0.60 log units) above the measured number, within the range that was stated.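

In this assay, within the data shown here, the earlier steps replaced the existing trifluoromethyl group, whereas this one keeps it and adds a second trifluoromethyl para to it, and the added group leaves the reading within the scatter: a 1.5-fold lower number from compound 1 to compound 4 (0.17 log units; within the scatter). This position on the ring therefore accepts a trifluoromethyl in place of hydrogen, and compound 4 gives a true number. Compound 2 and compound 3 remain limits of the assay: the limit of > 100000 nM in this assay, at which 2 of the 4 values shown sit.

From the compounds shown here alone, whether an amine or a carboxylic acid would be accepted at this same position stays open. One added group also says nothing about the other positions on this ring.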